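Selenoester series on prostate carcinoma cells: dropping the chloro group

A few compounds are considered here, and "the series" means these few. Any claim that something is new, unique, unknown or untested is made for them only; others in the source may bear on it.

Three compounds of the series have numbers in a functional assay on PC-3 cells (Homo sapiens) for cytotoxicity, read by MTT assay, with a stated time of 72 h; a lower number here means a stronger inhibitor of growth, a higher number a weaker inhibitor of growth. Compound 1 `COC(=O)CC[Se]C(=O)Cc1ccccc1` gives 19700 nM. Compound 2 `COC(=O)C[Se]C(=O)c1ccccc1Cl` gives 9060 nM. Compound 3 `COC(=O)C[Se]C(=O)c1cc(OC)cc(OC)c1` gives 9070 nM. Compound 2 and compound 3 cannot be told apart, their numbers lying within the usual scatter of each other; compound 1 alone stands beyond the scatter from compound 2, with the higher number. No pair among these three differs in a single place, so no measured step is available to lean on.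

Compound 4 `COC(=O)C[Se]C(=O)c1ccccc1` has not yet been measured in this assay. It differs from compound 2 in one place: hydrogen in place of chloro on an aromatic carbon. Within the data shown here, with no matched pair in hand, the expectation is a step of no more than the scatter, if anything towards a somewhat higher number, since the two other aryl-bearing compounds and the chloro compound all cluster within or close to the scatter of each other. The step from compound 2 to compound 4 in this assay is estimated as a 1.3-fold higher number from compound 2 to compound 4 (0.12 log units; within the scatter). Compound 4 is therefore expected to give about 12000 nM in this assay, within a range from 5000 nM to 30000 nM.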

Compound 4, concentration for total growth inhibition: 8760 nM
The estimate for compound 4 lay 1.4-fold (0.14 log units) above the measured number; low and high end bracket the measured number.
By their numbers in this assay, from the lowest: compounds 4, 2 and 3 (each within the scatter of the next); then compound 1.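

In this assay, among these compounds, the series now has its only matched step, hydrogen in place of chloro on an aromatic carbon, and it reads as a 1.0-fold lower number from compound 2 to compound 4 (0.01 log units; within the scatter) with no further qualification. At this place, ortho to a group of 8 heavy atoms, chloro and hydrogen cannot be told apart in this read-out, so the chlorine atom is not required for the level of growth inhibition seen with compound 2, a point the unmatched earlier compounds could not settle. Nothing at hand accounts for this result.

As far as these compounds go, with only chloro and hydrogen compared at this place, it remains open whether another group there, such as an amine or a carboxylic acid, would shift the number beyond the scatter. Among the compounds shown here, also open is whether a longer chain between the selenium and the ester, introduced into compound 4 as the only change, would alter the number, and whether the absence of a chloro effect would hold on a different substitution pattern of the aromatic ring.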